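The source may report more compounds than this note shows. Statements on the series, on what has been measured and on what is new or still open speak of the compounds shown alone.

Measured so far:
compound 1, `CC[C@H](C)[C@H](N)CN(C(=O)[C@@H]1C[C@H]1c1ccccc1)c1ccc(-c2ccccc2)cc1` — 230 nM; 800 nM (2 entries)
compound 2, `CC(C)C[C@@H](N)CN(C(=O)[C@@H]1C[C@H]1c1ccccc1)c1ccc(-c2ccccc2)cc1` — 1.8 nM
compound 3, `CN[C@@H](CC(C)C)CN(C(=O)[C@@H]1C[C@H]1c1ccccc1)c1ccc(-c2ccccc2)cc1` — 2 nM

In a functional assay for agonist activity at G protein-coupled receptor 88 (Homo sapiens), read by HTRF and cAMP accumulation (a higher number here means that more compound is needed for the effect, a lower number that less compound is needed), compound 3 stands alongside compound 2; the step of a 1.1-fold higher number from compound 2 to compound 3 (0.05 log units; within the scatter) is within the scatter, so the two are not told apart. Compound 1 has two readings in this assay and no single number, (the several entries of compound 1 in this assay, 230 nM; 800 nM (2 entries)), both well apart from compound 2 and compound 3.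

Compound 4 is `CC[C@H](C)[C@@H](CN(C(=O)[C@@H]1C[C@H]1c1ccccc1)c1ccc(-c2ccccc2)cc1)NC(C)=O`. The change 1-acetamido-2-methylbutyl in place of 3-methyl-1-(methylamino)butyl on a saturated chain carbon bound to an amide-type nitrogen has two parts: the chain carbon pattern returns to that of compound 1, and the methylamino group becomes an acetamido group. Within the data shown here, no measured step covers an acetamido group in this assay; only compound 1 bears on the chain, and its readings in this assay are far weaker than those of compound 2 and compound 3. The expected step of a 300-fold higher number from compound 3 to compound 4 (2.48 log units; beyond the scatter) is therefore a clear rise, beyond the scatter, with wide uncertainty. Compound 4 is estimated at 600 nM, in the range 100 nM to 4000 nM.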

Compound 4, half-maximal effective concentration: 5.8 nM
Beside the measured number, compound 4's estimate is 100-fold (2.01 log units) above it, outside the stated range (below it).
By their numbers in this assay, from the lowest: compounds 2 and 3 (each within the scatter of the next); then compound 4.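

In this assay, the nitrogen on this chain need not carry a free amino or methylamino group: the 1-acetamido-2-methylbutyl group costs only modest steps, a 2.9-fold higher number from compound 3 to compound 4 (0.46 log units; beyond the scatter) and a 3.2-fold higher number from compound 2 to compound 4 (0.51 log units; beyond the scatter). Both steps also change the carbon pattern of the chain, so neither isolates the acetamido group. The 2-methylbutyl pattern, which the earlier compounds showed only as a weak outlier, is compatible with a low reading once its nitrogen is acetylated, as compound 4 lies well under both entries of compound 1, which has the same chain with a free amino group: the several entries of compound 1 in this assay, 230 nM; 800 nM (2 entries)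

How much of the gap to compound 2 comes from the chain and how much from the acetamido group stays open, since an acetamido group on the 3-methylbutyl chain is not among the compounds shown. Also open, from the compounds shown here alone, is how a propanamido, urea or methanesulfonamido group on this nitrogen would read.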